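The source may report more compounds than this note shows. Statements on the series, on what has been measured and on what is new or still open speak of the compounds shown alone.

Measured compounds in a functional assay on HUVEC cells (Homo sapiens) for inhibition; a lower number here means a stronger inhibitor, a higher number a weaker inhibitor:

compound 1, `COc1cc(/C=C/C(=O)c2cccc(NC(=O)c3c(Cl)cccc3Cl)c2)ccc1O`, gives 0.46 ug/mL.
compound 2, `CCCC(=O)Nc1cccc(C(=O)/C=C/c2ccc(O)c(OC)c2)c1`, gives 1.27 ug/mL.
compound 3, `COc1cc(/C=C/C(=O)c2cccc(NC(=O)c3ccccc3)c2)ccc1O`, gives 0.37 ug/mL.

Among these three numbers compound 1 stands second highest. Its nearest neighbour is compound 3, and the step of a 1.2-fold lower number from compound 1 to compound 3 (0.09 log units; within the scatter) stays within the scatter, so the two cannot be told apart on this evidence. Its furthest neighbour is compound 2, reached by the step of a 2.8-fold higher number from compound 1 to compound 2 (0.44 log units; beyond the scatter), a modest change that does lie beyond the scatter. The third step, a 3.4-fold lower number from compound 2 to compound 3 (0.54 log units; beyond the scatter), closes the triangle.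

The unmeasured compound 4, `COc1cc(/C=C/C(=O)c2cccc(NC(C)=O)c2)ccc1O`, differs from compound 1 in one place: methyl in place of 2,6-dichlorophenyl on a carbonyl carbon. The measured steps that bear on this change are those at the same carbonyl carbon. Exchanging the 2,6-dichlorophenyl for phenyl left the number where it was, whereas exchanging it for propyl, a chain, raised the number modestly. Methyl is also a chain, and the shorter one, so the expectation rests chiefly on the step from compound 1 to compound 2 and places compound 4 on the same side of compound 1, at a similar or somewhat larger distance.

Compound 4 is therefore expected to give roughly 1.5 ug/mL in this assay, within a range of 0.7 ug/mL to 3.5 ug/mL, which corresponds to an expected step of a 3.3-fold higher number from compound 1 to compound 4 (0.51 log units; beyond the scatter).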

Compound 4, half-maximal inhibitory concentration: 7.06 ug/mL
Compound 4: middle estimate off by 4.7-fold (0.67 log units), on the low side; the measured number lies above the stated range.
By their numbers in this assay, from the lowest: compounds 3 and 1 (each within the scatter of the next); then compound 2; then compound 4.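

In this assay, within the data shown here, the group on the carbonyl carbon bound to the amide-type nitrogen proves far less tolerant of change than the earlier compounds suggested: replacing either aromatic group with methyl gives a 15-fold higher number from compound 1 to compound 4 (1.19 log units; beyond the scatter) and a 19-fold higher number from compound 3 to compound 4 (1.28 log units; beyond the scatter), both large, although phenyl and 2,6-dichlorophenyl could not be told apart. The two chains also differ from each other, as shown by a 5.6-fold higher number from compound 2 to compound 4 (0.75 log units; beyond the scatter), something that could not be seen while propyl was the only chain among the compounds. Across the four compounds the number falls from methyl to propyl and falls again to the two aromatic groups, but compound 1 and compound 3 stand within the scatter of each other, so the two chlorine atoms do not extend this trend.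

From the compounds shown here alone, whether a longer chain such as hexyl would continue the fall from methyl to propyl and approach the aromatic groups stays open, as does the effect of an amine or a carboxylic acid at the end of such a chain. Nothing available gives a measured reason for the size of these steps.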